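A few compounds are considered here, and "the series" means these few. Any claim that something is new, unique, unknown or untested is made for them only; others in the source may bear on it.

Compound 3 `O=C(Nc1nnc(-c2ccc(O)c(O)c2)s1)c1ccc(Cl)cc1` is one of three compounds tested in a functional assay on HL-60 cells (Homo sapiens) for cytotoxicity, read by MTT assay, with a stated time of 72 h (on this read-out higher numbers stand for weaker inhibition and lower numbers for stronger inhibition), where compound 3 gives 14700 nM. Compound 1 `O=C(Nc1nnc(-c2cccc(O)c2O)s1)c1ccccc1` gives 20700 nM and compound 2 `O=C(Nc1nnc(-c2cccc(O)c2O)s1)C1CCCCC1` gives 7900 nM; both of these numbers lie within the usual scatter of the number for compound 3, so no ordering among the three can be claimed. Compound 4 `CC(=O)Nc1nnc(-c2ccc(O)c(O)c2)s1` differs from compound 3 by methyl in place of 4-chlorophenyl on a carbonyl carbon. Within the data shown here, the only measured step at a carbonyl carbon is a 2.6-fold lower number from compound 1 to compound 2 (0.42 log units; beyond the scatter). That step swapped one ring for another, not a ring for a methyl, so it guides only loosely; a modest shift in either direction, or none beyond the scatter, seems possible. The number for compound 4 is therefore expected to stay near that of compound 3. The expected step is a 1.4-fold higher number from compound 3 to compound 4 (0.13 log units; within the scatter). Compound 4 is estimated at 20000 nM, with a range from 7000 nM to 60000 nM.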

Compound 4, half-maximal inhibitory concentration: 42500 nM
For compound 4 the middle estimate is 2.1-fold (0.33 log units) below the measured one; the measured number falls inside the stated range.
By their numbers in this assay, from the lowest: compounds 2, 3 and 1 (each within the scatter of the next, the first and the last beyond it); then compound 4.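

In this assay methyl in place of 4-chlorophenyl on a carbonyl carbon gives a 2.9-fold higher number from compound 3 to compound 4 (0.46 log units; beyond the scatter), a step beyond the scatter. The earlier step at such a carbon only exchanged one ring for another, whereas this one shows that the number also responds when the ring is removed altogether. No measurement available here explains this shift. Still open, from the compounds shown here alone, is whether a longer chain, such as butyl, or a cyclohexyl on this core would bring the number back towards that of compound 3. A plain phenyl here could show whether the chlorine matters.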